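A few compounds are considered here, and "the series" means these few. Any claim that something is new, unique, unknown or untested is made for them only; others in the source may bear on it.

Measured compounds:
- compound 1, `Cc1ccc(Nc2cc(NC(=O)Nc3c(Cl)cccc3Cl)ncn2)cc1C`: 73.3%
- compound 2, `COc1cc(NC(=O)Nc2cc(Nc3cc(I)ccc3OC)ncn2)cc(OC)c1`: 59%
- compound 3, `COc1cc(Nc2cc(NC(=O)Nc3c(Cl)cccc3Cl)ncn2)cc(C(F)(F)F)c1`: 32.3%

In a functional assay on NCI-H1581 cells (Homo sapiens) for inhibition, read by MTT assay, with a stated time of 48 h, tested at 10 uM (on this read-out lower numbers stand for less inhibition and higher numbers for more inhibition at the one concentration tested (going by the name of the read-out)), compound 1 gives 73.3%, the highest of the three numbers. Compound 2, at 59%, sits lower by a margin beyond the scatter, and compound 3, at 32.3%, is furthest from compound 1, again beyond the scatter. No pair among these three differs in a single place, so the numbers stand on their own and support no step within the set.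

Compound 4, `CCc1ccc(Nc2cc(NC(=O)Nc3c(Cl)cccc3Cl)ncn2)cc1`, is not yet measured. It shares all atoms with compound 1, joined differently: 4-ethylphenyl in place of 3,4-dimethylphenyl on a nitrogen on an aromatic ring. For the measured compounds named here, since this assay has no measured step of this kind, only a rough expectation is possible. The exchange keeps the shared core and the urea part of compound 1 unchanged, so a small step is expected, in either direction or none beyond the scatter, leaning slightly downward from the high value of compound 1.

For compound 4 the expected step is a number 10.3 percentage points lower from compound 1 to compound 4 (beyond the scatter). Compound 4 is therefore estimated at 63%, with a range from 42% to 80%.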

Compound 4, a percentage reported as inhibition, at one concentration (the size of the read-out at that concentration, not a potency): 38.1%
For compound 4 the middle estimate is 24.9 percentage points above the measured one; the measured number lies below the stated range.
By their numbers in this assay, from the lowest: compounds 3 and 4 (each within the scatter of the next); then compound 2; then compound 1.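

In this assay, for the compounds shown here, 4-ethylphenyl in place of 3,4-dimethylphenyl on a nitrogen on an aromatic ring gives a number 35.2 percentage points lower from compound 1 to compound 4 (beyond the scatter), the first step that can be read in a single place. The two groups have the same heavy-atom count and the same ring, so at this position the read-out responds to how the carbons are arranged on the phenyl ring, not only to which atoms are present. No measurement at hand accounts for the size of this step.

This single pair cannot separate the effect of the ethyl group from that of losing the two methyl groups. Going by these compounds, how a phenyl ring with one methyl group, a longer chain such as propyl, or an amine would behave at this nitrogen remains open.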